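A few compounds are considered here, and "the series" means these few. Any claim that something is new, unique, unknown or untested is made for them only; others in the source may bear on it.

Measured compounds in a functional assay on NCI/ADR-RES cells (Homo sapiens) for inhibition, read by sulforhodamine B assay, with a stated time of 48 h; a lower number here means a stronger inhibitor of growth, a higher number a weaker inhibitor of growth:
- compound 1, `COc1cc(-c2nn(-c3cccc(NC(=O)Nc4cc(C(F)(F)F)cc(C(F)(F)F)c4)c3)cc2-c2ccncc2)ccc1Cl`: 5180 nM
- compound 2, `COc1cc(-c2nn(-c3cccc(NC(=O)c4cccc(C(F)(F)F)c4)c3)cc2-c2ccncc2)ccc1Cl`: 3170 nM
- compound 3, `O=C(Nc1cccc(-n2cc(-c3ccncc3)c(-c3ccc(Cl)c(O)c3)n2)c1)Nc1ccc(Cl)c(Cl)c1`: > 32500 nM

The reading of compound 3 is a limit of this assay and not a number, as noted in the limit of > 32500 nM in this assay, at which 1 of the 3 values shown sits. Of the two numeric readings, compound 2 and compound 1 fall within the usual scatter of each other, so no order between them can be stated; compound 3 with its limit stands apart.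

Compound 4, `COc1cc(-c2nn(-c3cccc(NC(=O)Nc4cccc(C(F)(F)F)c4)c3)cc2-c2ccncc2)ccc1Cl`, has not yet been measured in this assay. Against compound 2 it differs in one place: (3-(trifluoromethyl)phenyl)amino in place of 3-(trifluoromethyl)phenyl on a carbonyl carbon. Within the data shown here, no measured pair in this set differs in that one place alone, so there is no step to lean on directly. Compound 1, a urea with a different trifluoromethyl-bearing aryl, gives a number within the scatter of compound 2; the only large departure in the set, compound 3, is a limit and carries two further changes. On this basis the step from compound 2 to compound 4 is expected to be small, a 1.3-fold higher number from compound 2 to compound 4 (0.10 log units; within the scatter), with no direction beyond the scatter. Compound 4 is therefore estimated at 4000 nM, between 1500 nM and 12000 nM.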

Compound 4, concentration for total growth inhibition: 3640 nM
The estimate for compound 4 lay 1.1-fold (0.04 log units) above the measured number, and the stated range covers the measured number.
By their numbers in this assay, from the lowest: compounds 2, 4 and 1 (each within the scatter of the next). At a limit, above all of these: compound 3.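

In this assay, among these compounds, the step of a 1.1-fold higher number from compound 2 to compound 4 (0.06 log units; within the scatter) is the first direct reading at the carbonyl carbon whose other neighbour is the amide-type nitrogen, since compound 1 also differs from compound 2 in a second place. At this position, (3-(trifluoromethyl)phenyl)amino and 3-(trifluoromethyl)phenyl are not told apart by this assay. The step of a 1.4-fold lower number from compound 1 to compound 4 (0.15 log units; within the scatter) adds a second reading, with hydrogen in place of trifluoromethyl on an aromatic carbon, and this change is not resolved either.

No measurement shown gives a reason for either step. Still open, going by these compounds, is whether a nitrile or a carboxylic acid in place of trifluoromethyl, or a longer chain in place of the amino link at the carbonyl carbon, would give a step beyond the scatter.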